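The compounds below may be only part of what the source reports. "The series", "measured", "known", "first", "only" and "open" are said of these compounds alone.

In a functional assay on SMMC-7721 cells (Homo sapiens) for inhibition, read by CCK-8 assay, with a stated time of 72 h (on this read-out higher numbers stand for weaker inhibition and lower numbers for stronger inhibition), compound 1 `Nc1ccccc1NC(=O)c1ccc(CNC(=O)c2n[nH]cc2NC(=O)c2ccccc2Cl)cc1` gives 12900 nM, compound 2 `Nc1ccccc1NC(=O)c1ccc(CNC(=O)c2n[nH]cc2NC(=O)c2ccccc2F)cc1` gives 6850 nM, and compound 3 `O=C(NO)c1ccc(CNC(=O)c2n[nH]cc2NC(=O)c2ccccc2F)cc1` gives 16700 nM. Compound 1 thus lies within the scatter of both other compounds. Compound 4 `Nc1ccccc1NC(=O)c1ccc(CNC(=O)c2n[nH]cc2NC(=O)c2c(F)cccc2F)cc1`, not yet measured, differs from compound 1 by 2,6-difluorophenyl in place of 2-chlorophenyl on a carbonyl carbon. The measured step that bears on this is a 1.9-fold lower number from compound 1 to compound 2 (0.27 log units; within the scatter), with fluoro in place of chloro on an aromatic carbon. The step of a 2.4-fold higher number from compound 2 to compound 3 (0.39 log units; beyond the scatter) changes an amide-type nitrogen instead and does not bear on it. A small move to a lower number in this assay, not beyond the scatter, is therefore expected, namely a 1.5-fold lower number from compound 1 to compound 4 (0.18 log units; within the scatter). For compound 4 the estimate is 8500 nM, with an expected range of 3500 nM to 20000 nM.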

Compound 4, half-maximal inhibitory concentration: 15200 nM
Compound 4: middle estimate off by 1.8-fold (0.25 log units), on the low side; the range from low to high includes it.
By their numbers in this assay, from the lowest: compounds 2, 1, 4 and 3 (each within the scatter of the next, the first and the last beyond it).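

In this assay, 2,6-difluorophenyl in place of 2-chlorophenyl on the carbonyl carbon gives a 1.2-fold higher number from compound 1 to compound 4 (0.07 log units; within the scatter), so the two groups cannot be told apart here. A further fluoro in place of hydrogen gives a 2.2-fold higher number from compound 2 to compound 4 (0.35 log units; beyond the scatter), showing that this aromatic ring can respond to a small change, here toward weaker inhibition. No measurement shown explains this shift.

On these data alone, it remains open how a plain phenyl, or a methoxy or an amine in place of the fluoro, would read. Also open, as far as these compounds go, is whether hydroxy in place of 2-aminophenyl would give a similar step alongside 2,6-difluorophenyl.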